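Thiophen-3-yl in place of thiophen-2-yl: notes on the series

A few compounds are considered here, and "the series" means these few. Any claim that something is new, unique, unknown or untested is made for them only; others in the source may bear on it.

Measured in a functional assay on K562 cells (Homo sapiens), read by MTT assay, with a stated time of 72 h; on this read-out lower numbers stand for stronger inhibition and higher numbers for weaker inhibition:
- compound 1 `CSc1ncnc2c1c(-c1ccsc1)cn2[C@@H]1O[C@H](CO)[C@@H](O)[C@H]1O` gives 450 nM
- compound 2 `CNc1ncnc2c1c(-c1ccsc1)cn2[C@@H]1O[C@H](CO)[C@@H](O)[C@H]1O` gives > 20000 nM (a limit)
- compound 3 `Cc1ncnc2c1c(-c1cccs1)cn2[C@@H]1O[C@H](CO)[C@@H](O)[C@H]1O` gives > 20000 nM (a limit)

Compound 3 has no number and sits on the limit of > 20000 nM in this assay, at which 2 of the 3 values shown sit, as its only result. Compound 4 `Cc1ncnc2c1c(-c1ccsc1)cn2[C@@H]1O[C@H](CO)[C@@H](O)[C@H]1O` has thiophen-3-yl in place of thiophen-2-yl on an aromatic carbon, and the two have the same atoms, joined differently: thiophen-3-yl in place of thiophen-2-yl on an aromatic carbon is the whole change.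

Among the compounds with values here, the one measured step is an at least 44-fold higher number from compound 1 to compound 2 (1.64 log units; beyond the scatter) and it is large, but it lies elsewhere on the shared core with thiophen-3-yl kept. It therefore does not measure this swap. Compound 1 carries thiophen-3-yl and gives 450 nM in this assay as a true number. Compound 2 carries the same group and gives > 20000 nM as a limit. Thiophen-3-yl thus goes with both outcomes, and neither compound shares the methyl group of compound 4.

Only a modest move toward lower numbers is expected, and it may stay hidden at the limit. The expected change is an at least 2.2-fold lower number from compound 3 to compound 4 (0.34 log units; beyond the scatter) in this assay as an estimate. For compound 4 the estimated value is 9000 nM with an expected range of 1500 nM to 20000 nM in this assay as the read-out.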

Compound 4, half-maximal inhibitory concentration: 320 nM
For compound 4 the middle estimate is 28-fold (1.45 log units) above the measured one, outside the stated range (below it).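

In this assay, this position tells the two thiophene attachments apart with the methyl group kept: thiophen-3-yl in place of thiophen-2-yl gives an at least 62-fold lower number from compound 3 to compound 4 (1.79 log units; beyond the scatter), although the groups match in every count of atoms, donors and acceptors. With thiophen-3-yl kept, the group elsewhere on the shared core also decides the outcome: methyl in place of methylamino gives an at least 62-fold lower number from compound 2 to compound 4 (1.79 log units; beyond the scatter), whereas methyl in place of methylsulfanyl gives a 1.4-fold lower number from compound 1 to compound 4 (0.15 log units; within the scatter), so that pair cannot be told apart. Neither group settles the result alone, since methyl goes with both outcomes across compound 3 and compound 4, and thiophen-3-yl goes with both across compound 2 and compound 4.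

From the compounds shown here alone, the true size of the two large steps stays open, since compound 2 and compound 3 each have only a limit and no number: the limit of > 20000 nM in this assay, at which 2 of the 4 values shown sit. Also open, going by these compounds, are whether thiophen-2-yl behaves differently with methylsulfanyl in place of methyl, and what an ethyl group, a primary amine or a furan-3-yl group would give on this core.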